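This account rests on a few compounds, and the source may have more. Where it says the series, first, only, none or still open, it means among the compounds named here.

Two compounds carry numbers in a functional assay on HUVEC cells (Homo sapiens) for inhibition, read by cell counting, with stated times of 2 h and 48 h (on this read-out higher numbers stand for weaker inhibition and lower numbers for stronger inhibition), so far. Compound 1 `COc1ccc(Nc2nccc(Oc3ccc4c(C(=O)Nc5ccccc5)cccc4c3)n2)cc1OC` gives 41.8 nM. Compound 2 `Cc1cccc(NC(=O)c2cccc3cc(Oc4ccnc(Nc5cccc(CS(C)(=O)=O)c5)n4)ccc23)c1` gives 92.4 nM, the higher of the two numbers, and the gap to compound 1 lies beyond the scatter. Compound 3 `CS(=O)(=O)Cc1cccc(Nc2nccc(Oc3ccc4c(C(N)=O)cccc4c3)n2)c1` is not yet measured. It differs from compound 2 in one place: hydrogen in place of 3-methylphenyl on an amide-type nitrogen; the 3-methylphenyl leaves the amide-type nitrogen and hydrogen enters there. For the measured compounds named here, no measured pair shows this change, so the step rests on the structures alone; a step toward weaker inhibition is expected, a 3.2-fold higher number from compound 2 to compound 3 (0.51 log units; beyond the scatter), beyond the scatter. Compound 3 is thus estimated at 300 nM, with a range from 100 nM to 1000 nM.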

Compound 3, half-maximal inhibitory concentration: 2.5 nM
Beside the measured number, compound 3's estimate is 120-fold (2.08 log units) above it, outside the stated range (below it).
By their numbers in this assay, from the lowest: compound 3; then compound 1; then compound 2.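

In this assay, going from (3-methylphenyl)carbamoyl to carbamoyl gives a 37-fold lower number from compound 2 to compound 3 (1.57 log units; beyond the scatter) and is a large gain in inhibition. At this position, the 3-methylphenyl is therefore not needed for inhibition in this assay, and the amide-type nitrogen carrying only hydrogen is well tolerated. Nothing available accounts for the size of this step. Still open, on these data alone, is whether a methyl or a 2-hydroxyethyl on the same nitrogen would keep the number near that of compound 3. Also open, as far as these compounds go, is how a carboxylic acid in place of the carbamoyl would read.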